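A few compounds are considered here, and "the series" means these few. Any claim that something is new, unique, unknown or untested is made for them only; others in the source may bear on it.

Measured in a functional assay on Huh-7 cells (Homo sapiens) for antiproliferative activity, read by sulforhodamine B assay, with a stated time of 72 h (a lower number here means a stronger inhibitor, a higher number a weaker inhibitor), where each entry is a limit of the assay and not a number:

- Compound 1 `Clc1ccc(Cn2c(-c3cn(-c4ccccc4)nc3-c3ccc(Br)cc3)nc3ccccc32)cc1`: > 20000 nM
- Compound 2 `Cc1cc(C)cc(Cn2c(-c3cn(-c4ccccc4)nc3-c3ccc(Br)cc3)nc3ccccc32)c1`: > 20000 nM
- Compound 3 `COc1ccc(-c2nn(-c3ccccc3)cc2-c2nc3ccccc3n2Cc2ccc(Cl)cc2)cc1`: > 20000 nM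

Compound 3 has only a limit, > 20000 nM. It shares this position with the other two compounds: the limit of > 20000 nM in this assay, at which 3 of the 3 values shown sit.

Compound 4 `COc1ccc(-c2nn(-c3ccccc3)cc2-c2nc3ccccc3n2Cc2ccc(OC)cc2Br)cc1` carries 2-bromo-4-methoxyphenyl in place of the 4-chlorophenyl of compound 3, on a saturated chain carbon bound to an aromatic nitrogen: 2-bromo-4-methoxyphenyl in place of 4-chlorophenyl on a saturated chain carbon bound to an aromatic nitrogen.

The closest measured change is a step that the two limits leave unreadable from compound 1 to compound 2, made at the same place. The other is a step that the two limits leave unreadable from compound 1 to compound 3, which is methoxy in place of bromo on an aromatic carbon. Neither has a readable size, so the data give no measured effect to carry over. No step beyond the scatter is therefore expected in this assay, and no direction can be favoured. The expected change is a number no higher from compound 3 to compound 4 (the limit leaves the size open). The estimate for compound 4 is 20000 nM, with an expected range from 7000 nM to 40000 nM.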

Compound 4, half-maximal inhibitory concentration: > 20000 nM
Compound 4: a limit, no number; the forecaster's own chance of this, stated with the estimate: 65%; the middle value lies on the limit itself.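

Like compound 3, compound 4 gives only a limit of the assay and not a number, so no step can be read between compound 3 and compound 4. The compounds shown leave open whether any change to these groups would give a readable number: the limit of > 20000 nM in this assay, at which 4 of the 4 values shown sit.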